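This account rests on a few compounds, and the source may have more. Where it says the series, first, only, none or still open, it means among the compounds named here.

Three compounds measured in a functional assay on cells (Cancer cell lines, Homo sapiens) for cytotoxicity, with a stated time of 48 h (a lower number here means a stronger inhibitor of growth, a higher number a weaker inhibitor of growth), set the scene. Compound 1, with structure `COc1c(/C=C2/C(=O)Nc3ccccc32)c2ccccc2n1-c1ccccc1`, gives 3470 nM in this assay, the lowest number of the three. Compound 2, with structure `COc1ccc2c(c1)/C(=C\c1c(Cl)n(C/C=C/c3ccccc3)c3ccccc13)C(=O)N2`, gives 16200 nM, and compound 3, with structure `COc1ccc2c(c1)/C(=C\c1c(Cl)n(Cc3cc(OC)c(OC)c(OC)c3)c3cc(C)c(OC)cc13)C(=O)N2`, gives 95500 nM. Both of these numbers lie well beyond the usual scatter above the value of compound 1, so compound 1 is the strongest growth inhibitor among the measured set; compounds 2 and 3 differ from it in several places at once, so their values show only that they are weaker, not why.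

Compound 4, with structure `COc1c(/C=C2/C(=O)Nc3ccc(Cl)cc32)c2ccccc2n1-c1ccccc1`, has not yet been measured. It differs from compound 1 by a single change: chloro in place of hydrogen on an aromatic carbon, a chloro in place of hydrogen on an aromatic carbon, sitting on a six-membered aromatic ring of carbon only that is part of a fused system of two rings. For the measured compounds named here, no measured pair in this set shows what such a change does, so no step can be read off. The expected step from compound 1 to compound 4 is a 1.4-fold lower number from compound 1 to compound 4 (0.14 log units; within the scatter), a modest shift that may not clear the scatter. Compound 4 is therefore estimated to give 2500 nM, within a range from 800 nM to 8000 nM.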

Compound 4, concentration for total growth inhibition: 24000 nM
Compound 4: middle estimate off by 9.6-fold (0.98 log units), on the low side, and the stated range ends below it.
By their numbers in this assay, from the lowest: compound 1; then compounds 2 and 4 (each within the scatter of the next); then compound 3.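

In this assay, chloro in place of hydrogen on this aromatic carbon, meta to a fused ring and para to a fused ring, gives a 6.9-fold higher number from compound 1 to compound 4 (0.84 log units; beyond the scatter) and so weakens growth inhibition instead of leaving it unchanged. For the compounds shown here, this is the first pair in the set that differs in one place only, so the loss can be tied to this single change on the core of compound 1. It shows that this position is not indifferent to substitution: one chlorine atom here is enough to move the value beyond the usual scatter, though nothing measured alongside these values speaks to the reason for the loss.

The compounds shown leave open whether the loss belongs to chloro itself or would follow any group placed on this carbon: on this core, only hydrogen and chloro can be compared here, and a fluoro or an amine in the same place would tell those two readings apart. They also leave open whether chloro on other aromatic carbons of the core would give a similar step.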